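The source may hold more compounds than are shown below. What is called first, only, known or untested is meant among the compounds shown, and "the series" means these compounds.

Measured compounds:
- compound 1 `COc1cc(N(CC2CC2)c2ccccc2)cnc1C(=O)[C@H]1C[C@@H]1C(=O)O` gives 158 nM
- compound 2 `COc1cc(N(CC2CC2)c2ccc(Cl)c3ccccc23)cnc1C(=O)CCCC(=O)O` gives 109 nM
- compound 3 `CCN(c1cnc(C(=O)[C@H]2C[C@@H]2C(=O)O)c(OC)c1)c1ccc(F)c2ccccc12` gives 1.05 nM

In an assay for inhibition of leukotriene C4 synthase (Homo sapiens), read by LC-MS, with stated times of 15 min and 30 min (a higher number here means a weaker inhibitor, a lower number a stronger inhibitor), compound 1 stands highest of the three. Its number and that of compound 2 lie within the scatter of each other, while compound 3 sits far lower, beyond the scatter. Compound 4 `COc1cc(N(CC2CC2)c2cc(Cl)ccc2F)cnc1C(=O)[C@H]1C[C@@H]1C(=O)O` arises from compound 1 by 5-chloro-2-fluorophenyl in place of phenyl on a nitrogen on an aromatic ring. Among the compounds with values here, no measured pair isolates this change, so its size is uncertain. Compound 3, carrying a halogenated aryl on the same nitrogen, shows how low this series can go with 1.05 nM. A downward step of moderate size in this assay is therefore expected for compound 4, a 5.3-fold lower number from compound 1 to compound 4 (0.72 log units; beyond the scatter). The estimate for compound 4 is 30 nM, with a range from 8 nM to 120 nM.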

Compound 4, half-maximal inhibitory concentration: 3.71 nM
Compound 4: middle estimate off by 8.1-fold (0.91 log units), on the high side, and the stated range ends above it.
By their numbers in this assay, from the lowest: compound 3; then compound 4; then compounds 2 and 1 (each within the scatter of the next).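

In this assay, within the data shown here, the change to 5-chloro-2-fluorophenyl in place of phenyl on the nitrogen gives a 43-fold lower number from compound 1 to compound 4 (1.63 log units; beyond the scatter) and is the only single-place comparison here. It shows that, with the rest of compound 1 unchanged, the aryl group at this position alone can produce a large step. Nothing measured here explains the size of that step. Whether the chlorine, the fluorine or the two together account for it stays open. So does the outcome with a nitrile or a methoxy group on this phenyl ring.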